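The compounds below may be only part of what the source reports. "The series", "measured", "known", "first", "only" and "open" are said of these compounds alone.

Values in an ADME assay on MT4 cells (Homo sapiens) for cytotoxicity, read by MTT assay, with a stated time of 5 days (on this read-out lower numbers stand for higher toxicity in this test and higher numbers for lower toxicity in this test), each a limit of the assay:
- compound 1 `COc1cc2cc(C#N)ccc2c(OC)c1Oc1cc(NC(C)(C)C)nc(Nc2ccc(C#N)cc2)n1`: > 125000 nM
- compound 2 `COc1cc2cc(C#N)ccc2c(OC)c1Oc1cc(NC2CCCC2)nc(Nc2ccc(C#N)cc2)n1`: > 125000 nM

Compound 2 stands at > 125000 nM, which is a limit and not a number. The shared core is unchanged in compound 3 `COc1cc2cc(C#N)ccc2c(OC)c1Oc1cc(NCCC2=CCCCC2)nc(Nc2ccc(C#N)cc2)n1`, which has 2-(cyclohex-1-en-1-yl)ethyl in place of cyclopentyl on a nitrogen on an aromatic ring.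

Among the compounds with values here, the only measured step bearing on this is a step that the two limits leave unreadable from compound 1 to compound 2, with cyclopentyl in place of tert-butyl, and it gives no size. The evidence amounts to the limit of > 125000 nM in this assay, at which 2 of the 2 values shown sit. Any expectation therefore rests on that ceiling alone: compound 3 will probably stay at the limit or fall modestly beneath it. The estimated step is an at least 1.2-fold lower number from compound 2 to compound 3 (0.09 log units; that floor lies within the scatter), towards lower numbers in this assay if it shows at all. The expected value for compound 3 is 100000 nM, with an estimated range of 25000 nM to 200000 nM.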

Compound 3, half-maximal cytotoxic concentration: > 125000 nM
Compound 3 ended at the assay's limit (the forecaster's own chance of this, stated with the estimate: 55%); at least 1.2-fold (0.09 log units) between middle value and limit.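

In this assay compound 3 gives > 125000 nM as a limit and not a number. No step among compound 1, compound 2 and compound 3 can be read, as each ends at a limit: the limit of > 125000 nM in this assay, at which 3 of the 3 values shown sit.

On these data alone, whether any group on this nitrogen gives a number beneath that limit stays open.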